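The source may report more compounds than this note shows. Statements on the series, on what has been measured and on what is new or still open speak of the compounds shown alone.

Of the compounds shown here, three with a shared core have numbers so far in a functional assay on MV4-11 cells (Homo sapiens) for antiproliferative activity, read by luminescence and CellTiter-Glo, with a stated time of 72 h (on this read-out lower numbers stand for stronger inhibition and higher numbers for weaker inhibition), and differ in the group on a saturated chain carbon bound to an aromatic nitrogen. Compound 1 `CNc1cc(-c2ccc3cnn(Cc4ccc(F)c(F)c4)c3c2)cn(C)c1=O` gives 320 nM here. Compound 2 `CNc1cc(-c2ccc3cnn(Cc4ccc(F)c([N+](=O)[O-])c4)c3c2)cn(C)c1=O` gives 130 nM here. Compound 3 `CNc1cc(-c2ccc3cnn(CC4CCCCC4)c3c2)cn(C)c1=O` gives 2690 nM and is the weakest of the three, with the highest number. Compound 4 `CCOC(=O)Cn1ncc2ccc(-c3cc(NC)c(=O)n(C)c3)cc21` has no number yet. It carries ethoxycarbonyl in place of cyclohexyl on a saturated chain carbon bound to an aromatic nitrogen. Going by the values given here, no measured step makes this exact swap. Nearest are the modest 8.4-fold higher number from compound 1 to compound 3 (0.92 log units; beyond the scatter) and the large 21-fold higher number from compound 2 to compound 3 (1.32 log units; beyond the scatter) at the same place, while the modest 2.5-fold lower number from compound 1 to compound 2 (0.39 log units; beyond the scatter) shows a smaller change on the aromatic ring. Because an 8.4-fold higher number from compound 1 to compound 3 (0.92 log units; beyond the scatter) shows that this place can move the number, a modest further rise in this assay is expected, with wide uncertainty. The estimated change is a 1.9-fold higher number from compound 3 to compound 4 (0.27 log units; within the scatter) toward weaker inhibition. For compound 4 the estimated value is 5000 nM with an expected range from 1500 nM to 16000 nM in such measurements.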

Compound 4, half-maximal inhibitory concentration: 8770 nM
For compound 4 the middle estimate is 1.8-fold (0.24 log units) below the measured one; low and high end bracket the measured number.
By their numbers in this assay, from the lowest: compound 2; then compound 1; then compound 3; then compound 4.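

In this assay, swapping the cyclohexyl ring for the ring-free ethoxycarbonyl, which counts two hydrogen-bond acceptors, gives a 3.3-fold higher number from compound 3 to compound 4 (0.51 log units; beyond the scatter), which makes compound 4 the weakest of the four. The gap to the compounds with an aromatic ring at this place is wider, at a 27-fold higher number from compound 1 to compound 4 (1.44 log units; beyond the scatter) and a 67-fold higher number from compound 2 to compound 4 (1.83 log units; beyond the scatter), so among these four, all three compounds with a ring on the saturated chain carbon give lower numbers than the one without. No measured evidence here explains these rises.

Going by these compounds alone, it remains open whether a carboxylic acid or an amide at this place would stay as weak as ethoxycarbonyl, or whether only this particular group gives so high a number. A plain longer carbon chain, or a ring holding an amine, would help separate the effect of having a ring from that of the atoms it contains.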